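Shortening the chain of compound 2

This account rests on a few compounds, and the source may have more. Where it says the series, first, only, none or still open, it means among the compounds named here.

For the measured compounds named here, in a functional assay on SK-HEP1 cells (Homo sapiens) for inhibition, read by MTT assay, with a stated time of 72 h (a higher number here means a weaker inhibitor, a lower number a stronger inhibitor), compound 2 (`Nc1ncnc2c1c(-c1cnc3[nH]ccc3c1)nn2CCCCCCCCC(=O)NO`) gives 11200 nM, the higher of the two numbers so far, while compound 1 (`CNC(=O)CCCCCCCn1nc(-c2cnc3[nH]ccc3c2)c2c(N)ncnc21`) gives 3950 nM. Compound 3 (`Nc1ncnc2c1c(-c1cnc3[nH]ccc3c1)nn2CCCCCC(=O)NO`) has a shorter chain, with hydroxycarbamoyl in place of 3-(hydroxycarbamoyl)propyl, on a saturated chain carbon, five bonds along the chain from an aromatic nitrogen (hydroxycarbamoyl in place of 3-(hydroxycarbamoyl)propyl on a saturated chain carbon, five bonds along the chain from an aromatic nitrogen). Going by the values given here, only one measured step bears on this, a 2.8-fold higher number from compound 1 to compound 2 (0.45 log units; beyond the scatter), where a longer chain came with a higher number. That step also changes the end group, so it is a weak guide. A modest move to a lower number is expected, a 2.5-fold lower number from compound 2 to compound 3 (0.40 log units; beyond the scatter). For compound 3 the estimated value is 4500 nM, within an expected range of 900 nM to 16000 nM.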

Compound 3, half-maximal inhibitory concentration: > 150000 nM
Compound 3 gave a limit, no number (the forecaster's own chance of this, stated with the estimate: 5%); middle value at least 33-fold (1.52 log units) from the limit.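

In this assay compound 3 gives a limit of the assay and not a number: the limit of > 150000 nM in this assay, at which 1 of the 3 values shown sits. The steps are still readable, and both are large: an at least 13-fold higher number from compound 2 to compound 3 (1.12 log units; beyond the scatter), and an at least 37-fold higher number from compound 1 to compound 3 (1.57 log units; beyond the scatter). So, at this place on the chain, the shorter chain ending in hydroxycarbamoyl gives a larger change than the step seen earlier between the two longer chains, and it runs towards a higher number, not a lower one.

The compounds shown leave open how a chain of intermediate length ending in hydroxycarbamoyl would behave. They also leave open whether a carboxylic acid or methylcarbamoyl at the end of the short chain would give a measurable number.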